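Replacing a bulky carbamate with a small hydroxyacetamide

This account rests on a few compounds, and the source may have more. Where it says the series, first, only, none or still open, it means among the compounds named here.

Measured so far in a functional assay on HCC827 cells (Homo sapiens) for antiproliferative activity, read by MTT assay, with a stated time of 72 h; on this read-out lower numbers stand for stronger inhibition and higher numbers for weaker inhibition:
compound 1 `CN1CCN(c2ccc(Nc3ncc4nc(Nc5ccc(F)cc5)n(-c5cccc(NC(=O)CO)c5)c4n3)cc2)CC1` gives 7.5 nM;
compound 2 `CN1CCN(c2ccc(Nc3ncc4nc(Nc5ccc(F)cc5)n([C@H]5CCN(C(=O)OC(C)(C)C)C5)c4n3)cc2)CC1` gives 580 nM;
compound 3 `CN1CCN(c2ccc(Nc3ncc4nc(Nc5ccc(F)cc5)n([C@@H]5CCN(C(=O)OC(C)(C)C)C5)c4n3)cc2)CC1` gives 27 nM.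

Compound 3 sits in the middle: the step of a 3.6-fold higher number from compound 1 to compound 3 (0.56 log units; beyond the scatter) is modest, while a 21-fold lower number from compound 2 to compound 3 (1.33 log units; beyond the scatter) is large, and the fact that compounds 2 and 3 differ only in the configuration as drawn shows that the latter step rests on configuration alone. Compound 4 `CN1CCN(c2ccc(Nc3ncc4nc(Nc5ccc(F)cc5)n([C@H]5CCN(C(=O)CO)C5)c4n3)cc2)CC1` keeps the same ring and arrangement but carries the change (1-((hydroxymethyl)carbonyl)pyrrolidin-3-yl in place of 1-(tert-butoxycarbonyl)pyrrolidin-3-yl on an aromatic nitrogen). The hydroxyacetamide group also appears in compound 1, which gives the lowest number of the three, so no large loss is expected; a small gain or no change beyond the scatter seems most likely. The expected step is a 1.4-fold lower number from compound 3 to compound 4 (0.13 log units; within the scatter), and compound 4 is therefore estimated at 20 nM, within 5 nM to 120 nM.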

Compound 4, half-maximal inhibitory concentration: 380 nM
Beside the measured number, compound 4's estimate is 19-fold (1.28 log units) below it; the measured number lies above the stated range.
By their numbers in this assay, from the lowest: compound 1; then compound 3; then compounds 4 and 2 (each within the scatter of the next).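

Compound 4 has the drawn configuration of compound 2, so the one-place comparison is with compound 2: hydroxymethyl in place of tert-butoxy on the carbonyl carbon gives a 1.5-fold lower number from compound 2 to compound 4 (0.18 log units; within the scatter). The large step, a 14-fold higher number from compound 3 to compound 4 (1.15 log units; beyond the scatter), spans that swap plus a change of configuration, and it points to configuration rather than the carbonyl substituent because of this: the fact that compounds 2 and 3 differ only in the configuration as drawn. The step of a 51-fold higher number from compound 1 to compound 4 (1.70 log units; beyond the scatter) shows that the hydroxymethyl carbonyl alone does not bring the low number of compound 1.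

As far as these compounds go, whether hydroxymethyl would match tert-butoxy on the configuration of compound 3 stays open. So does the effect of an aminomethyl group on that carbonyl carbon.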